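A few compounds are considered here, and "the series" means these few. Any claim that something is new, unique, unknown or untested is made for them only; others in the source may bear on it.

Compound 1 `O=C1/C(=C/c2ccncc2)CN(S(=O)(=O)c2ccc([N+](=O)[O-])cc2)C/C1=C\c1ccccc1F`: 8800 nM
Compound 2 `O=C1/C(=C/c2ccncc2)CN(S(=O)(=O)c2ccc(C(F)(F)F)cc2)C/C1=C\c1ccccc1F`: 9500 nM
Compound 3 `O=C1/C(=C/c2ccncc2)CN(S(=O)(=O)c2ccc([N+](=O)[O-])cc2)C/C1=C\c1ccccc1C(F)(F)F`: not yet measured

Among the compounds with values here, in a functional assay on QGY-7703 cells (Homo sapiens) for cytotoxicity, read by MTT assay, with a stated time of 24 h (a lower number here means a stronger inhibitor, a higher number a weaker inhibitor), compound 1 cannot be separated from compound 2, the only other compound with a number, so the two cannot be ranked. The gap between them is small: a 1.1-fold higher number from compound 1 to compound 2 (0.03 log units; within the scatter).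

Compound 3 keeps the core of compound 1 and changes one group: trifluoromethyl in place of fluoro on an aromatic carbon. In words, trifluoromethyl takes the place of fluoro on an aromatic carbon, turning 2-fluorophenyl into 2-(trifluoromethyl)phenyl.

Within the data shown here, only one measured step offers any guidance, and it is indirect. Going to compound 2 also brought in trifluoromethyl on an aromatic carbon, but there it replaced nitro, not fluoro. That step stayed within the scatter: a 1.1-fold higher number from compound 1 to compound 2 (0.03 log units; within the scatter). Among the measured compounds shown here, no measured compound shows what happens when the fluoro itself is exchanged, so the expectation is uncertain, and no step beyond the scatter is expected in this assay. The expected change is small: a 1.0-fold higher number from compound 1 to compound 3 (0.01 log units; within the scatter). The estimate for compound 3 is 9000 nM, with an expected range from 4000 nM to 20000 nM.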

Compound 3, half-maximal inhibitory concentration: 9730 nM
Beside the measured number, compound 3's estimate is 1.1-fold (0.03 log units) below it, and the stated range covers the measured number.
By their numbers in this assay, from the lowest: compounds 1, 2 and 3 (each within the scatter of the next).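

In this assay, within the data shown here, the earlier pair varied only the nitro group, whereas compound 3 is the first to vary the 2-fluorophenyl group, and exchanging it for 2-(trifluoromethyl)phenyl gives a 1.1-fold higher number from compound 1 to compound 3 (0.04 log units; within the scatter) for this change. The place on the aromatic ring ortho to a large group therefore takes trifluoromethyl, with its 4 heavy atoms, in place of fluoro, with its 1 heavy atom, and the step stays within the usual scatter of this kind of measurement. This is a second part of the molecule where a single exchange leaves the number within the scatter, although that statement covers only these three compounds. Nothing measured here offers a reason for this result.

As far as these compounds go, it remains open whether this place would respond to a group of a different kind, such as an amine, a carboxylic acid or a longer chain in place of fluoro. Also open, from the compounds shown here alone, is whether the two exchanges to trifluoromethyl, each within the scatter on its own, would stay within it if combined in a single molecule.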